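The compounds below may be only part of what the source reports. "The series", "measured", "known", "first", "only" and "open" are said of these compounds alone.

Values measured in a functional assay on DU-145 cells (Homo sapiens) for inhibition, read by MTT assay, with a stated time of 72 h; on this read-out lower numbers stand for stronger inhibition and higher numbers for weaker inhibition:

- Compound 1 `O=S(=O)(Oc1ccccc1)[C@H]1C[C@H]2O[C@@H]1C(c1ccc(O)cc1)=C2c1ccc(O)cc1` gives > 100000 nM, which is a limit of the assay.
- Compound 2 `O=C(O)CCCCCCC(=O)Nc1ccc(C2=C(c3ccc(O)cc3)C3CC(S(=O)(=O)Oc4cccc5ccccc45)C2O3)cc1` gives 48600 nM.
- Compound 3 `O=C(CCCCCCC(=O)Nc1ccc(C2=C(c3ccc(O)cc3)C3CC(S(=O)(=O)Oc4ccccc4)C2O3)cc1)NO` gives 37700 nM.

Compound 2 has a measured number in this assay, and its nearest neighbour is compound 3. The values of these two compounds lie within the usual scatter of each other, so neither can be ranked over the other. Compound 1 is known only through its limit of > 100000 nM.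

The next compound to be tested in this assay is compound 4 `O=C(O)CCCCCCC(=O)Nc1ccc(C2=C(c3ccc(O)cc3)C3CC(S(=O)(=O)Oc4ccc(C(F)(F)F)cc4)C2O3)cc1`. It differs from compound 2 in one place: 4-(trifluoromethyl)phenyl in place of naphthalen-1-yl on an oxygen. In words, 4-(trifluoromethyl)phenyl stands in place of naphthalen-1-yl on an oxygen whose other neighbour is the sulfonyl sulfur.

Among the measured compounds shown here, no pair of measured compounds differs in only one place, so the data give no direct size for this change. Starting from compound 2 at 48600 nM, no step beyond the scatter is expected, and neither direction is favoured. The estimated change is a 1.1-fold lower number from compound 2 to compound 4 (0.03 log units; within the scatter). For compound 4 the expected value is 45000 nM, with an estimated range from 18000 nM to 100000 nM.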

Compound 4, half-maximal inhibitory concentration: 77000 nM
Beside the measured number, compound 4's estimate is 1.7-fold (0.23 log units) below it; low and high end bracket the measured number.
By their numbers in this assay, from the lowest: compounds 3, 2 and 4 (each within the scatter of the next, the first and the last beyond it). At a limit, above all of these: compound 1.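

Among the compounds shown here, this is the first measured step at the group on the oxygen whose other neighbour is the sulfonyl sulfur: in this assay, placing 4-(trifluoromethyl)phenyl where naphthalen-1-yl stood gives a 1.6-fold higher number from compound 2 to compound 4 (0.20 log units; within the scatter). The exchange takes the group from two six-membered aromatic rings to one and brings in fluorine at an unchanged heavy-atom count, yet the read-out does not separate the two compounds, so this pair gives no ranking of the two groups. Compound 1 sits at a limit of the assay, and numbers in this range have little room upward before reaching it: the limit of > 100000 nM in this assay, at which 1 of the 4 values shown sits.

The compounds shown leave open whether a phenyl ring carrying an amine or a nitrile, or a plain methyl group, on this oxygen would move the number beyond the scatter. They also leave open whether the same exchange would give a similar step on a compound with a shorter chain in place of the one ending in the carboxylic acid.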